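Ring Methyl on Compound 2: Expected Maximal Response

The source may hold more compounds than are shown below. What is called first, only, known or untested is meant among the compounds shown, and "the series" means these compounds.

Measured compounds:
compound 1 `CC(C)(C)OC(=O)N1CCC(O[C@H]2CC[C@H](Oc3ccc(C#N)cc3)CC2)CC1`: 116%
compound 2 `CC(C)OC(=O)N1CCC(O[C@H]2CC[C@H](Oc3ccc(S(C)(=O)=O)nc3)CC2)CC1`: 101%

In a functional assay on isolated protein for agonist activity at Glucose-dependent insulinotropic receptor (Homo sapiens), read by HTRF and cAMP accumulation (a lower number here means a smaller maximal response, a higher number a larger maximal response), compound 1 gives 116%, and in this assay compound 2 gives 101%. Compound 2 stands lowest of the two numbers; its nearest neighbour is compound 1, a number higher by an amount beyond the scatter. The two compounds differ in more than one place, so no single step connects them and nothing can be said about the cause of the gap.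

Compound 3 `Cc1nc(S(C)(=O)=O)ccc1O[C@H]1CC[C@H](OC2CCN(C(=O)OC(C)C)CC2)CC1` has not yet been measured. It differs from compound 2 by methyl in place of hydrogen on an aromatic carbon; the methyl enters on an aromatic carbon next to the ring nitrogen, ortho to a large group and meta to the methylsulfonyl group. Within the data shown here, no pair of measured compounds isolates this change. Given that compound 2 already reaches 101% in this assay, a change of this size is expected to move the maximal response by no more than the scatter, with no clear direction. The step of a number 1 percentage points lower from compound 2 to compound 3 (within the scatter) is therefore expected to be small. Compound 3 is estimated at 100%, with a range from 85% to 115%.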

Compound 3, largest response reached (Emax), in percent of the reference or control that the assay uses: 108%
For compound 3 the middle estimate is 8 percentage points below the measured one; the measured number falls inside the stated range.
By their numbers in this assay, from the lowest: compounds 2, 3 and 1 (each within the scatter of the next, the first and the last beyond it).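

In this assay, methyl in place of hydrogen on the aromatic carbon next to the ring nitrogen gives a number 7 percentage points higher from compound 2 to compound 3 (within the scatter), so at this position, with the methylsulfonyl group and the isopropyl carbamate held constant, the added methyl leaves the maximal response within the scatter of the hydrogen compound. Among these compounds, this is the first single-place comparison: compound 1 and compound 2 differ in more than one place, so their values said nothing about this ring position, whereas compound 3, at 108%, shows that this position accepts a methyl in this assay. No supporting measurement is available that bears on the reason for this step.

Whether the same position also accepts an ethyl group, a methoxy group, a chlorine atom, an amine or a carboxylic acid remains open, as the methyl is the only replacement for hydrogen shown here. Also open, going by these compounds, is whether methyl on the other aromatic carbons of this ring, or on the nitrile-bearing ring of compound 1, would stay within the scatter in the same way.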